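Bromo Exchanged for Propyl on a Pyridine Ether

A few compounds are considered here, and "the series" means these few. Any claim that something is new, unique, unknown or untested is made for them only; others in the source may bear on it.

Of the compounds shown here, two have so far been measured in an assay on K177 cells with Neuronal acetylcholine receptor; alpha4/beta2 (Homo sapiens) as the target; on this read-out lower numbers stand for smaller maximal responses and higher numbers for larger maximal responses. Compound 1 `CN1CCC[C@H]1COc1cccnc1Br` gives 12.3%. Compound 2 `CN1CCC[C@H]1COc1cncc(Br)c1` gives 41.8%. Going by the values given here, of these two numbers, compound 2 stands highest; its only neighbour, compound 1, lies lower by a gap that is beyond the usual scatter of repeated measurements.

The next compound, compound 3 `CCCc1cncc(OC[C@@H]2CCCN2C)c1`, has not yet been measured. It differs from compound 2 in one place: propyl in place of bromo on an aromatic carbon. Among the compounds with values here, no measured pair shows this kind of exchange, so there is no step from which its effect could be read off. Within the data shown here, both compounds measured so far carry bromo, so neither shows what propyl does in its place.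

With nothing to lean on, the expected step in this assay is a number 6.8 percentage points lower from compound 2 to compound 3 (within the scatter), a small move downward that stays within the scatter. Compound 3 is therefore estimated to reach 35% in this assay, with a range from 10% to 70% that reflects how little the measured data say about this change.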

Compound 3, largest response reached (reported as maximum), in percent of the reference or control that the assay uses: 13%
The estimate for compound 3 lay 22 percentage points above the measured number, within the range that was stated.
By their numbers in this assay, from the lowest: compounds 1 and 3 (each within the scatter of the next); then compound 2.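

Propyl in place of bromo on this aromatic carbon, two atoms from the ring nitrogen, is the first exchange of one group for another that can be read in this assay, and it brings a number 28.8 percentage points lower from compound 2 to compound 3 (beyond the scatter) as a modest step. The two bromo compounds differ only in where the bromo sits, so they could not show whether the group at this place matters; this step shows that the maximal response does not hold when the single bromine gives way to a chain of three carbons. No measurement at hand says why the number falls with this exchange.

As far as these compounds go, it remains open whether a shorter chain such as methyl or ethyl, a longer chain such as butyl, or an amine or a carboxylic acid on this same carbon would restore the number of compound 2 or leave it down. Also open, from the compounds shown here alone, is whether propyl in place of bromo at the place the bromo occupies in compound 1 would bring a step of similar size.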